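Bromo-to-chloro step repeated on a second core

The source may report more compounds than this note shows. Statements on the series, on what has been measured and on what is new or still open speak of the compounds shown alone.

Compound 1 `COc1ccc(C2=NN(C3=NC(=O)/C(=C4\C(=O)Nc5ccc(Br)cc54)S3)C(c3ccc(OC)cc3)C2)cc1` and compound 2 `COc1ccc(C2=NN(C3=NC(=O)/C(=C4\C(=O)Nc5ccc(Cl)cc54)S3)C(c3ccc(OC)cc3)C2)cc1` share one core; compound 3 `CN(C)c1ccc(C2CC(c3ccccc3)=NN2C2=NC(=O)/C(=C3\C(=O)Nc4ccc(Br)cc43)S2)cc1` and compound 4 `CN(C)c1ccc(C2CC(c3ccccc3)=NN2C2=NC(=O)/C(=C3\C(=O)Nc4ccc(Cl)cc43)S2)cc1` share another, and the difference between the two cores is not broken down here. In a functional assay on cells (Cancer cell lines, Homo sapiens) for cytotoxicity, read by sulforhodamine B assay, with a stated time of 48 h (a lower number here means a stronger inhibitor of growth, a higher number a weaker inhibitor of growth), compound 1 gives 32500 nM, and compound 2 gives 21200 nM. The step of a 1.5-fold lower number from compound 1 to compound 2 (0.19 log units; within the scatter) accompanies (chloro in place of bromo on an aromatic carbon). Compound 3 gives 690 nM in this assay, the lowest of the three numbers, with compound 2 the nearest and compound 1 the furthest, both gaps beyond the scatter. Compound 4 differs from compound 3 by chloro in place of bromo on an aromatic carbon; the place reads the same as for the change from compound 1 to compound 2, so it is the same change, made once on each core, two occurrences in all. Among the compounds with values here, the only measured example of this change, the one from compound 1 to compound 2, lies within the scatter. For compound 4 the expectation is therefore a step of a 1.3-fold lower number from compound 3 to compound 4 (0.12 log units; within the scatter) of about that same size, resting on that single pair alone. Compound 4 is therefore estimated at 520 nM, from 250 nM to 1100 nM.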

Compound 4, concentration for total growth inhibition: 620 nM
Estimate against measurement, compound 4: 1.2-fold (0.08 log units) below; low and high end bracket the measured number.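

In this assay the chloro-for-bromo change on the core of compound 3 gives a 1.1-fold lower number from compound 3 to compound 4 (0.05 log units; within the scatter), so no shift in growth inhibition can be read from this pair. Set beside the earlier pair, the change reads alike on both cores: the same change on two cores in this assay, a 1.5-fold lower number (0.19 log units; within the scatter) from compound 1 to compound 2 and a 1.1-fold lower number (0.05 log units; within the scatter) from compound 3 to compound 4, 1.4-fold (0.14 log units) apart, within the scatter of two such steps. This shows agreement between two cores only, and both steps lie within the scatter, so there is no effect of measurable size to carry across and nothing here extends to any third core.

Open, from the compounds shown here alone, is whether a group other than bromo or chloro at this place, such as fluoro, methyl, methoxy or an amine, would leave the read-out equally unmoved on either core. Also open is which of the differences between the two cores goes with the gap in their values, since the compounds shown do not separate the dimethylamino-bearing aryl group from the other aryl changes.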